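The compounds below may be only part of what the source reports. "The series", "measured", "known", "first", "only" and "open" are said of these compounds alone.

Measured compounds:
Compound 1, `CC(C)(N)C(=O)N[C@H](COCc1ccc(F)cc1F)c1nnnn1CCOC(=O)NCCCCO`, gives 0.42 nM in a functional assay on cells for inhibition of growth hormone secretagogue receptor type 1 (Homo sapiens), read by FLIPR and calcium flux; a lower number here means that less compound is needed, a higher number that more compound is needed for the effect.
Compound 2, `CC(C)(N)C(=O)N[C@H](COCc1cccc(Cl)c1)c1nnnn1CCOC(=O)NCCCCO`, gives 1.6 nM.
Compound 3, `CC(C)(N)C(=O)N[C@H](COCc1ccccc1C(F)(F)F)c1nnnn1CCOC(=O)NCCCCO`, gives 0.72 nM.

All three share one core and differ only in the aryl group carried on the saturated chain carbon bound to an oxygen on a saturated carbon. Compound 3 holds the second highest of the three numbers: one step is a 1.7-fold higher number from compound 1 to compound 3 (0.23 log units; within the scatter), while the other is a 2.2-fold lower number from compound 2 to compound 3 (0.35 log units; beyond the scatter). The widest spread among the measured compounds is a 3.8-fold higher number from compound 1 to compound 2 (0.58 log units; beyond the scatter).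

Compound 4, `CC(C)(N)C(=O)N[C@H](COCc1ccccc1C#N)c1nnnn1CCOC(=O)NCCCCO`, is not yet measured. It differs from compound 3 in one place: cyano in place of trifluoromethyl on an aromatic carbon. Among the compounds with values here, no measured step swaps cyano for trifluoromethyl, so only the general picture applies: the three aryl changes seen so far moved the numbers at most modestly, and two of the three steps fell close to or within the scatter. On that basis a change in this assay is expected to be small, if it shows at all, with no direction clearly favoured.

Compound 4 is therefore estimated to give 1 nM, between 0.3 nM and 3.5 nM, an expected step of a 1.4-fold higher number from compound 3 to compound 4 (0.14 log units; within the scatter).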

Compound 4, half-maximal effective concentration: 1.26 nM
Compound 4: the middle estimate sits 1.3-fold (0.10 log units) below what was measured, within the range that was stated.
By their numbers in this assay, from the lowest: compounds 1, 3, 4 and 2 (each within the scatter of the next, the first and the last beyond it).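

In this assay, cyano in place of trifluoromethyl on an aromatic carbon ortho to a large group gives a 1.8-fold higher number from compound 3 to compound 4 (0.24 log units; within the scatter), so this position accepts a group of 2 heavy atoms with 1 hydrogen-bond acceptor in place of one of 4 heavy atoms with none, with no change that stands clear of the scatter. The 2-cyanophenyl group also cannot be told apart from 3-chlorophenyl, with a 1.3-fold lower number from compound 2 to compound 4 (0.10 log units; within the scatter), whereas it can be told apart from 2,4-difluorophenyl, with a 3.0-fold higher number from compound 1 to compound 4 (0.48 log units; beyond the scatter). Nothing available explains these differences in the numbers.

From the compounds shown here alone, whether an amine, a carboxylic acid or a longer chain on that same aromatic carbon would keep the number in this range remains open. Going by these compounds, all four compounds share the rest of their structure, so it is also open whether cyano in place of trifluoromethyl would give a similar step on a different core.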